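The source may hold more compounds than are shown below. What is called first, only, known or untested is meant among the compounds shown, and "the series" means these compounds.

Compound 1 `Cc1cc(C(C)C)ccc1OC(c1ccc(Cl)cc1)c1cnc(NC(=O)OC(C)(C)C)s1`: > 50000 nM
Compound 2 `CC(C)(C)OC(=O)Nc1ncc(C(Oc2ccc3cc(Br)ccc3c2)c2ccc(Cl)cc2)s1`: > 50000 nM

In an ADME assay on HepG2 2.2.15 cells (Homo sapiens) for cytotoxicity (a higher number here means that more compound is tolerated, a lower number that less compound is tolerated), compound 1 gives only a limit, > 50000 nM. Compound 2 likewise gives only a limit, > 50000 nM. Both results sit at the same limit (the limit of > 50000 nM in this assay, at which 2 of the 2 values shown sit), so the step that the two limits leave unreadable from compound 1 to compound 2 cannot be read in size or direction. Compound 3 `Clc1ccc(C(Oc2ccc3cc(Br)ccc3c2)c2cnc(NCC3CCCCC3)s2)cc1` differs from compound 2 in one place: cyclohexylmethyl in place of tert-butoxycarbonyl on a nitrogen on an aromatic ring. Among the compounds with values here, no measured step covers this change, and the single measured step is unreadable, so no direction is indicated. The expected step is an at least 1.2-fold lower number from compound 2 to compound 3 (0.09 log units; that floor lies within the scatter). Compound 3 is therefore estimated at 40000 nM, with a range from 10000 nM to 100000 nM.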

Compound 3, half-maximal cytotoxic concentration: "not toxic" (no number reported)
Compound 3 has no reported number here; there is nothing to compare the estimate with.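

Within the data shown here, compound 3 is reported only as "not toxic", with no number, so no step from compound 2 to compound 3 can be read. The compounds shown leave open whether either change shifts the result in this assay at all.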